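Swapping Benzyl for tert-Butyl on the Double-Bonded Nitrogen

This account rests on a few compounds, and the source may have more. Where it says the series, first, only, none or still open, it means among the compounds named here.

Of the compounds shown here, three sharing a core have been measured in a functional assay on A549 cells (Homo sapiens) for inhibition, read by MTT assay, with a stated time of 24 h (on this read-out lower numbers stand for stronger inhibition and higher numbers for weaker inhibition), so far. Compound 1 `[O-]/[N+](=C\c1cn(-c2ccc(Cl)cc2)nn1)c1ccccc1` gives 10500 nM there. Compound 2 `COc1ccc(-n2cc(/C=[N+](\[O-])Cc3ccccc3)nn2)cc1` reaches only a limit of the assay, namely > 100000 nM in this read-out. Compound 3 `[O-]/[N+](=C\c1cn(-c2ccc(C(F)(F)F)cc2)nn1)Cc1ccccc1` likewise reaches only a limit, namely > 100000 nM in the same read-out. Within the data shown here, the single measured step that changes one place, a step that the two limits leave unreadable from compound 2 to compound 3, cannot be sized, since both its ends sit at the limit of > 100000 nM in this assay, at which 2 of the 3 values shown sit. Compound 3 therefore stands at the weak edge of the numbers shown, with no finite value known for it.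

Compound 4 `CC(C)(C)/[N+]([O-])=C/c1cn(-c2ccc(C(F)(F)F)cc2)nn1` differs from compound 3 in one place: tert-butyl in place of benzyl on a double-bonded nitrogen. Among the measured compounds shown here, no measured step touches this change; compound 1 and compound 3 differ in more than one place, so their two values form no step. Nothing in the data sets a size or direction for the step in this assay. With compound 3 already at a limit, compound 4 is expected to stay close, giving a step that the limit leaves unreadable from compound 3 to compound 4 as the expected step. Compound 4 is estimated at 120000 nM, within 30000 nM to 500000 nM, and most likely reported again as a limit.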

Compound 4, half-maximal inhibitory concentration: 43600 nM
Compound 4: middle estimate off by 2.8-fold (0.44 log units), on the high side; low and high end bracket the measured number.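

In this assay, the change at the double-bonded nitrogen gives the first readable step among these compounds: an at least 2.2-fold lower number from compound 3 to compound 4 (0.36 log units; beyond the scatter). Among these compounds, the earlier compounds could not show this, since the only step between them had a limit at both ends, whereas here the swap of benzyl for tert-butyl brings a finite number out of the limit. The step is only a minimum, because compound 3 stands at a limit and its true value could lie further away: the limit of > 100000 nM in this assay, at which 2 of the 4 values shown sit.

From the compounds shown here alone, how far the number would move with a cyclohexyl group or a longer chain on this nitrogen stays open. Going by these compounds, it is also open whether tert-butyl lowers the number in the same way when methoxy replaces trifluoromethyl on the aromatic carbon.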